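The compounds below may be only part of what the source reports. "The series", "measured", "known", "first", "only" and "open" are said of these compounds alone.

Of the compounds shown here, three have been measured, and a fourth awaits its result. Compound 1 `O=C(/C=C\Nc1ccc(Cl)cc1)c1cn(-c2ccccc2)nc1-c1ccc(F)cc1` gives 3800 nM in a functional assay on PC-3 cells (Homo sapiens) for antiproliferative activity, read by MTT assay, with a stated time of 48 h; on this read-out higher numbers stand for weaker inhibition and lower numbers for stronger inhibition. Compound 3 `O=C(/C=C\Nc1ccc(Cl)cc1)c1cn(-c2ccccc2)nc1-c1ccc(Cl)cc1` gives 3890 nM in this assay. Compound 2 `COc1cc(N/C=C\C(=O)c2cn(-c3ccccc3)nc2-c2ccc(F)cc2)cc(OC)c1OC` has a core that differs from that of compound 1 in a way that is not broken down here. In this assay compound 2 gives 4890 nM. The three numbers lie within the usual scatter of one another, so no order among them can be claimed.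

The change from compound 1 to compound 3 is chloro in place of fluoro on an aromatic carbon, and it made the step of a 1.0-fold higher number from compound 1 to compound 3 (0.01 log units; within the scatter). The same change, (chloro in place of fluoro on an aromatic carbon), leads from compound 2 to compound 4 `COc1cc(N/C=C\C(=O)c2cn(-c3ccccc3)nc2-c2ccc(Cl)cc2)cc(OC)c1OC`, which has not yet been measured in this assay.

The expectation for compound 4 rests on one comparison only. Compound 4 is expected to stand close to the number of its parent because the step of a 1.0-fold higher number from compound 1 to compound 3 (0.01 log units; within the scatter) showed this exchange leaving the number essentially where it was. From compound 2 the estimated step to compound 4 in this assay is a 1.0-fold higher number from compound 2 to compound 4 (0.01 log units; within the scatter). Compound 4 is accordingly estimated at 5000 nM in this assay, with a plausible range from 2500 nM to 10000 nM. A single precedent is a thin basis, and the scatter of the measurement itself is wide enough that a result anywhere within that range would be unsurprising.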

Compound 4, half-maximal inhibitory concentration: 9980 nM
Compound 4: the middle estimate sits 2.0-fold (0.30 log units) below what was measured; the range from low to high includes it.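

In this assay, the exchange of 4-fluorophenyl for 4-chlorophenyl on the core of compound 2 gave a 2.0-fold higher number from compound 2 to compound 4 (0.31 log units; beyond the scatter), a modest step and the only one of the two that rises above the scatter. Set beside the same exchange on the core of compound 1, the two steps cannot be told apart: the same change on two cores in this assay, a 1.0-fold higher number (0.01 log units; within the scatter) from compound 1 to compound 3 and a 2.0-fold higher number (0.31 log units; beyond the scatter) from compound 2 to compound 4, 2.0-fold (0.30 log units) apart, within the scatter of two such steps. Within the data shown here, the series therefore gives no sign that the core alters what this change does, yet with only two pairs it does not establish that the change carries over unaltered either, and the gap between the steps may be measurement scatter or a small real difference that these numbers cannot resolve.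

The compounds shown leave open how other groups would behave at the same place on the aromatic ring, such as bromo, methyl or trifluoromethyl, and whether any of them would move the number further than chloro does on either core. They also leave open whether a third core would follow compound 1 to compound 3 or compound 2 to compound 4, and whether an amine or a carboxylic acid elsewhere on the shared core would change this picture.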